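A few compounds are considered here, and "the series" means these few. Any claim that something is new, unique, unknown or untested is made for them only; others in the source may bear on it.

Measured so far in a functional assay on KYSE-410 cells (Homo sapiens) for antiproliferative activity, read by MTT assay, with a stated time of 72 h; on this read-out lower numbers stand for stronger inhibition and higher numbers for weaker inhibition:
- compound 1 `O=C(Nc1cccc(F)c1)c1cc(=O)[nH]c2cc(Br)ccc12`: 7300 nM
- compound 2 `O=C(Nc1cccc(F)c1)c1cc(=O)[nH]c2cc(-c3ccc(F)cc3)ccc12`: 10300 nM

Going by the values given here, compound 2 sits within the scatter of compound 1, the only other measured compound, so the two cannot be ranked. The next compound is compound 3 `COc1ccc(-c2ccc3c(C(=O)Nc4cccc(F)c4)cc(=O)[nH]c3c2)cc1`, with methoxy in place of fluoro on an aromatic carbon, para to a large group: methoxy in place of fluoro on an aromatic carbon. Among the compounds with values here, no measured step tests this exchange directly. The nearest evidence is a 1.4-fold higher number from compound 1 to compound 2 (0.15 log units; within the scatter), where 4-fluorophenyl replaced bromo. That large replacement left the number within the scatter, so no step beyond the scatter is expected in this assay, in either direction. The expected change is a 1.0-fold lower number from compound 2 to compound 3 (0.01 log units; within the scatter). For compound 3 the estimated value is 10000 nM, with an expected range of 4500 nM to 22000 nM.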

Compound 3, half-maximal inhibitory concentration: 18000 nM
Compound 3: the middle estimate sits 1.8-fold (0.26 log units) below what was measured; measured number inside the range.
By their numbers in this assay, from the lowest: compounds 1, 2 and 3 (each within the scatter of the next, the first and the last beyond it).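

In this assay, methoxy in place of fluoro on an aromatic carbon, para to a large group, gives a 1.7-fold higher number from compound 2 to compound 3 (0.24 log units; within the scatter) and so cannot be separated from repeat-measurement variation. Across the same position, 4-methoxyphenyl in place of bromo gives a 2.5-fold higher number from compound 1 to compound 3 (0.39 log units; beyond the scatter) and is the first step in the series beyond the scatter, modest in size and toward weaker inhibition. No measured evidence is available to explain this step.

The compounds shown leave open whether the weaker inhibition belongs to 4-methoxyphenyl specifically or extends to other groups at this position. An amine, a carboxylic acid or a longer alkoxy chain in place of methoxy would test how far the number can move in either direction from this site.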